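A few compounds are considered here, and "the series" means these few. Any claim that something is new, unique, unknown or untested is made for them only; others in the source may bear on it.

The study measures growth inhibition in a functional assay on MDA-MB-231 cells (Homo sapiens) for inhibition, read by sulforhodamine B assay, with a stated time of 48 h; on this read-out higher numbers stand for weaker inhibition of growth and lower numbers for stronger inhibition of growth. The measured compounds and their values:

Compound 1 `CCOC(=O)[C@H](CCC(=O)O)NC(=O)c1ccc(Sc2nc3cc(N)cc(N)c3nc2-c2ccccc2)cc1` gives 7940 nM.
Compound 2 `COc1ccc(CNc2nc3cc(N)cc(N)c3nc2-c2ccccc2)cc1` gives 2880 nM.
Compound 3 `COc1ccc(Sc2nc3cc(N)cc(N)c3nc2-c2ccccc2)cc1` gives < 100000 nM.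

Compound 3 stands apart from the other two, since its figure is not a number but a limit of the measurement, as stated in the limit of < 100000 nM in this assay, at which 1 of the 3 values shown sits. So where compound 3 stands among the numbers shown cannot be told; its value is simply the limit. Compound 1 and compound 2 carry numbers, and compound 2 sits at the lower figure.

Compound 4 `Nc1cc(N)c2nc(-c3ccccc3)c(Sc3ccc(F)cc3)nc2c1` follows from compound 3 by one change: fluoro in place of methoxy on an aromatic carbon. Because compound 3 carries only a limit < 100000 nM, no measured step anchors this change, and no shown pair repeats it. The expectation for compound 4 therefore rests on the numbers of compound 1 and compound 2, which share the core, and on the change being a small swap on an aromatic carbon. The step that the limit leaves unreadable from compound 3 to compound 4 is expected to lie within the scatter rather than beyond it. Compound 4 is estimated at 8000 nM, within a range from 1500 nM to 50000 nM.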

Compound 4, concentration for 50% growth inhibition: 17400 nM
Compound 4: the middle estimate sits 2.2-fold (0.34 log units) below what was measured, within the range that was stated.
By their numbers in this assay, from the lowest: compound 2; then compound 1; then compound 4.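

The step from compound 3 to compound 4 cannot be read, because compound 3 carries a limit and not a number: the limit of < 100000 nM in this assay, at which 1 of the 4 values shown sits.

The compounds shown leave open how far fluoro in place of methoxy shifts growth inhibition: no pair with two measured numbers carries this change.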